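Working notes: from compound 3 to compound 4

The source may report more compounds than this note shows. Statements on the series, on what has been measured and on what is new or still open speak of the compounds shown alone.

- compound 1 `C=C(Br)C(=O)Nc1cccc(/C=C/C(=O)Nc2ccccc2)c1`: 16600 nM
- compound 2 `C=C(Br)C(=O)Nc1cccc(/C=C/C(=O)Nc2cccc(F)c2)c1`: 4600 nM
- compound 3 `C=C(Br)C(=O)Nc1cccc(/C=C/C(=O)Nc2ccc(F)c(F)c2)c1`: 8700 nM

All three values come from a functional assay on HT-29 cells (Homo sapiens) for inhibition, read by MTT assay, with a stated time of 72 h; a higher number here means a weaker inhibitor, a lower number a stronger inhibitor. Compound 3 gives 8700 nM and lies within the scatter of both other compounds. The data show a 1.9-fold lower number from compound 1 to compound 3 (0.28 log units; within the scatter) and a 1.9-fold higher number from compound 2 to compound 3 (0.28 log units; within the scatter). Going by the values given here, the only step beyond the scatter is a 3.6-fold lower number from compound 1 to compound 2 (0.56 log units; beyond the scatter), and it is modest.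

The next compound is compound 4 `C=C(Br)C(=O)Nc1cccc(/C=C/C(=O)NCc2ccc(C)cc2)c1`, with 4-methylbenzyl in place of 3,4-difluorophenyl on an amide-type nitrogen.

Among the compounds with values here, no measured step tests a 4-methylbenzyl group. The closest guide is the exchange of the whole group on that nitrogen, seen in a 1.9-fold lower number from compound 1 to compound 3 (0.28 log units; within the scatter), which stays within the scatter. The other two steps only add a fluoro to an aromatic carbon. Within the data shown here, compound 4 carries no fluoro, and the one compound without fluoro, compound 1, gives 16600 nM, so a lean towards a higher number is expected, though not a step clearly beyond the scatter. The estimated step is a 1.4-fold higher number from compound 3 to compound 4 (0.14 log units; within the scatter). The wider change leaves the uncertainty large. For compound 4 the estimated value is 12000 nM, with an expected range of 4500 nM to 32000 nM.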

Compound 4, half-maximal inhibitory concentration: 2700 nM
The estimate for compound 4 lay 4.4-fold (0.65 log units) above the measured number; measured number outside the range, below it.
By their numbers in this assay, from the lowest: compounds 4, 2, 3 and 1 (each within the scatter of the next, the first and the last beyond it).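

In this assay, the group on the amide-type nitrogen can be more than a phenyl ring carrying fluoro: 4-methylbenzyl in place of 3,4-difluorophenyl, with the same count of heavy atoms but all of them carbon, gives a 3.2-fold lower number from compound 3 to compound 4 (0.51 log units; beyond the scatter) and stands clear of the scatter, whereas the earlier exchange of the whole group on this nitrogen did not. The same group gives a 6.1-fold lower number from compound 1 to compound 4 (0.79 log units; beyond the scatter) against the unsubstituted phenyl, while the comparison with the 3-fluorophenyl of compound 2 gives a 1.7-fold lower number from compound 2 to compound 4 (0.23 log units; within the scatter), so fluoro is not required on this group for a number in the range of compound 2. No measurement at hand bears on why this exchange shifts the number.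

The 4-methylbenzyl group differs from the earlier groups both in its benzyl link and in its methyl, and a plain benzyl or a 4-methylphenyl group on this nitrogen would separate the two. A longer chain such as phenethyl, or an amine on the ring, would show how far this position extends beyond the groups seen so far.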